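This account rests on a few compounds, and the source may have more. Where it says the series, first, only, none or still open, it means among the compounds named here.

Measured so far in a functional assay on ECa-109 cells (Homo sapiens) for antiproliferative activity, read by MTT assay, with a stated time of 48 h; a higher number here means a weaker inhibitor, a lower number a stronger inhibitor:

compound 1, `Cn1cc(C2=C(c3n[nH]c4ncccc34)C(=O)N(c3cccc4ccccc34)C2=O)c2ccccc21` — > 100000 nM (a limit of the assay, not a number)
compound 2, `Cn1cc(C2=C(c3nn(CCCn4cccc4)c4ncccc34)C(=O)N(c3ccccc3)C2=O)c2ccccc21` — > 100000 nM (a limit of the assay, not a number)
compound 3, `Cn1cc(C2=C(c3nn(CCCCn4ccnc4)c4ncccc34)C(=O)NC2=O)c2ccccc21` — 23500 nM

Compound 1 stands at the limit only: in this assay it gives no number, and it shares that position with one further compound, as noted in the limit of > 100000 nM in this assay, at which 2 of the 3 values shown sit. For the measured compounds named here, compound 3 is the only member of the set with a measured value, and compound 1 cannot be ranked against it beyond saying that its own reading is a limit. Going by the values given here, no step between two measured compounds that differ in one place is available, so no measured step sets the scale.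

Compound 4, `Cn1cc(C2=C(c3nn(CCCN4CCCCC4)c4ncccc34)C(=O)N(c3cccc4ccccc34)C2=O)c2ccccc21`, is the next member to be tested. It differs from compound 1 by 3-(piperidin-1-yl)propyl in place of hydrogen on an aromatic nitrogen. With compound 1 at the limit, the starting point is itself uncertain, and the expected step from compound 1 to compound 4 is set at an at least 1.6-fold lower number from compound 1 to compound 4 (0.22 log units; that floor lies within the scatter), that is, a gain in this assay of a size beyond the scatter but no more. Compound 4 is accordingly expected to give 60000 nM in this assay, with a range from 15000 nM to 200000 nM.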

Compound 4, half-maximal inhibitory concentration: 1830 nM
Compound 4: middle estimate off by 33-fold (1.52 log units), on the high side; the measured number lies below the stated range.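

In this assay compound 1 gives > 100000 nM, which is a limit of the assay and not a number. The aromatic nitrogen of the five-membered ring emerges as a position where substitution can go with a large gain: 3-(piperidin-1-yl)propyl in place of hydrogen gives an at least 54-fold lower number from compound 1 to compound 4 (1.73 log units; beyond the scatter), the only measured step among the compounds shown and so the only scale available for this series. That step is a floor rather than a full size, and the true change from hydrogen remains unknown: the limit of > 100000 nM in this assay, at which 2 of the 4 values shown sit.

The compounds shown leave open whether the gain follows from the piperidine ring or from the propyl chain alone. They also do not tell how a morpholine ring, a dimethylamino group or a longer chain at this nitrogen would read in this assay.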